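The source may hold more compounds than are shown below. What is called first, only, known or untested is meant among the compounds shown, and "the series" means these compounds.

Measured so far in this set:

Compound 1, `Cc1ccc(C(C)C)c(OC(=O)Nc2ccc([N+](=O)[O-])cc2)c1`: 51.7%
Compound 2, `Cc1ccc(C(C)C)cc1OC(=O)NC1CCCC1`: 63.3%
Compound 3, `Cc1ccc(C(C)C)cc1OC(=O)Nc1cccc(F)c1`: 64.4%

All three numbers come from a toxicity assay on the whole organism (H4IIE cells) for cytotoxicity, with Rattus norvegicus as the target, read by MTT assay, with a stated time of 24 h, tested at 0.6 uM; a higher number here means a weaker effect of the compound at the concentration tested, a lower number a stronger effect. Compound 3 stands at the top of the three. Among the measured compounds shown here, its margin over compound 1 is beyond the usual scatter, whereas compound 2 sits so close that the two cannot be told apart; the one step between measured neighbours, a number 1.1 percentage points higher from compound 2 to compound 3 (within the scatter), shows exactly that.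

The unmeasured compound 4, `Cc1ccc(C(C)C)cc1OC(=O)Nc1ccccc1`, differs from compound 3 in one place: hydrogen in place of fluoro on an aromatic carbon. For the measured compounds named here, none of the measured steps involves the same change, since the only step in hand swaps a cyclopentyl for a 3-fluorophenyl on the amide-type nitrogen and is itself within the scatter. There is thus no measured ground for a shift in this assay in either direction, and the sensible expectation is a step that stays within the scatter.

Compound 4 is therefore estimated to give 64%, in the range 52% to 76%, which would mean an expected step of a number 0.4 percentage points lower from compound 3 to compound 4 (within the scatter) from its fluorinated neighbour.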

Compound 4, a percentage reported as activity, at one concentration (the size of the read-out at that concentration, not a potency): 82.5%
For compound 4 the middle estimate is 18.5 percentage points below the measured one; measured number outside the range, above it.
By their numbers in this assay, from the lowest: compound 1; then compounds 2 and 3 (each within the scatter of the next); then compound 4.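

In this assay, among the compounds shown here, hydrogen in place of fluoro on the aromatic carbon gives a number 18.1 percentage points higher from compound 3 to compound 4 (beyond the scatter) and so, at this place, the fluoro goes with a stronger effect at the concentration tested, something the earlier compounds could not show. The group on the amide-type nitrogen also takes on a meaning it did not have before: phenyl in place of cyclopentyl gives a number 19.2 percentage points higher from compound 2 to compound 4 (beyond the scatter) while 3-fluorophenyl in place of cyclopentyl gave only a number 1.1 percentage points higher from compound 2 to compound 3 (within the scatter) in the same read-out. For these three compounds, then, an aromatic ring on that nitrogen does not by itself stay level with the cyclopentyl compound, and it does so only when the fluoro is present.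

As far as these compounds go, whether this shift belongs to fluoro in particular or would come with any group on that carbon stays open, and a chloro or a methoxy group in the same place would separate the two readings. Nothing in hand accounts for the size of the step, and the compounds shown offer no measurement that would explain it.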